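Adding a Methoxy Group to Compound 2

A few compounds are considered here, and "the series" means these few. Any claim that something is new, unique, unknown or untested is made for them only; others in the source may bear on it.

Measured compounds:
compound 1 `COc1cc(-c2cc(/C=C/C(=O)c3ccc(N)cc3)[nH]n2)cc(OC)c1OC` 3670 nM
compound 2 `COc1ccc(C(=O)/C=C/c2cc(-c3cc(OC)c(OC)c(OC)c3)n[nH]2)cc1OC` 3090 nM

In a functional assay on ACHN cells (Homo sapiens) for inhibition, read by sulforhodamine B assay, with a stated time of 48 h (a lower number here means a stronger inhibitor of growth, a higher number a weaker inhibitor of growth), compound 1 gives 3670 nM and compound 2 gives 3090 nM. The number for compound 2 is the lower of the two, yet a 1.2-fold lower number from compound 1 to compound 2 (0.07 log units; within the scatter) lies within the scatter, so the pair is not separated. Compound 3 `COc1cc(C(=O)/C=C/c2cc(-c3cc(OC)c(OC)c(OC)c3)n[nH]2)cc(OC)c1OC` differs from compound 2 by methoxy in place of hydrogen on an aromatic carbon. Within the data shown here, no measured step adds a methoxy group; the one step on hand is small, so the change to compound 3 is expected to be a 1.2-fold lower number from compound 2 to compound 3 (0.07 log units; within the scatter) in this assay, with no clear direction. Compound 3 is estimated at 2600 nM, ranging from 900 nM to 8000 nM.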

Compound 3, concentration for total growth inhibition: 3010 nM
Beside the measured number, compound 3's estimate is 1.2-fold (0.06 log units) below it, and the stated range covers the measured number.
By their numbers in this assay, from the lowest: compounds 3, 2 and 1 (each within the scatter of the next).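

In this assay, methoxy in place of hydrogen on an aromatic carbon, at a spot ortho to a methoxy group, gives a 1.0-fold lower number from compound 2 to compound 3 (0.01 log units; within the scatter). The earlier step swapped a whole group on the carbonyl carbon, whereas this one probes a single position on that ring and does not separate compound 3 from compound 2. Nothing at hand explains this result.

Still open, going by these compounds, is whether a different group at this position, such as an amine, a carboxylic acid or a longer chain like butoxy, would separate from compound 2.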